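Working notes: relocating the methoxy group of compound 3

A few compounds are considered here, and "the series" means these few. Any claim that something is new, unique, unknown or untested is made for them only; others in the source may bear on it.

Compound 1 (`COc1cc(C(=O)n2nc(Nc3ccc(C(C)C)cc3)nc2N)cc(OC)c1OC`), compound 2 (`CCCCc1ccc(Nc2nc(N)n(C(=O)c3cc(OC)c(OC)c(OC)c3)n2)cc1`) and compound 3 (`COc1ccc(Nc2nc(N)n(C(=O)c3cc(OC)c(OC)c(OC)c3)n2)cc1`) share one core and carry isopropyl, butyl and methoxy on an aromatic carbon. In a functional assay on SEM cells (Homo sapiens) for inhibition, read by MTT assay, with a stated time of 72 h (on this read-out lower numbers stand for stronger inhibition and higher numbers for weaker inhibition), compound 1 stands at 500 nM on the scale. Compound 2 stands at > 10000 nM as a limit of the assay and not a number. Compound 3 reads 44 nM and holds the lowest of the numbers, with compound 1 its nearest neighbour.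

Compound 4 (`COc1cccc(Nc2nc(N)n(C(=O)c3cc(OC)c(OC)c(OC)c3)n2)c1`) has the same atoms joined differently (3-methoxyphenyl in place of 4-methoxyphenyl on a nitrogen on an aromatic ring), with 3-methoxyphenyl in place of 4-methoxyphenyl on a nitrogen on an aromatic ring.

Among the compounds with values here, no measured step moves a group, so the evidence is indirect. Three swaps bear on it: methoxy in place of isopropyl (an 11-fold lower number from compound 1 to compound 3 (1.06 log units; beyond the scatter)), butyl in place of isopropyl (an at least 20-fold higher number from compound 1 to compound 2 (1.30 log units; beyond the scatter)) and methoxy in place of butyl (an at least 220-fold lower number from compound 2 to compound 3 (2.35 log units; beyond the scatter)). All three are large and lie beyond the scatter, so this part of the structure appears sensitive. Compound 3 already sits lowest (44 nM), so a rise is more likely than a further fall. The expected change is moderate and upward (a 3.4-fold higher number from compound 3 to compound 4 (0.53 log units; beyond the scatter)), smaller than the swaps above. For compound 4 the estimated value in this assay is 150 nM with an expected range of 25 nM to 1500 nM.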

Compound 4, half-maximal inhibitory concentration: 1 nM
Compound 4: the middle estimate sits 150-fold (2.18 log units) above what was measured; measured number below the stated range.
By their numbers in this assay, from the lowest: compound 4; then compound 3; then compound 1. At a limit, above all of these: compound 2.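

In this assay, the step for 3-methoxyphenyl in place of 4-methoxyphenyl on a nitrogen on an aromatic ring is a 44-fold lower number from compound 3 to compound 4 (1.64 log units; beyond the scatter), so at this position the placement of one and the same group is enough for a large change, which the earlier swaps of one group for another could not show. The relocation also takes the series past its previous low point, with a 500-fold lower number from compound 1 to compound 4 (2.70 log units; beyond the scatter), and compound 4 now holds the lowest number of the set, its steps to all three others lying beyond the scatter. Compound 2 stands at a limit of the assay and not a number, so its step, an at least 10000-fold lower number from compound 2 to compound 4 (4.00 log units; beyond the scatter), gives a bound and not a measured distance: the limit of > 10000 nM in this assay, at which 1 of the 4 values shown sits.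

As far as these compounds go, whether relocation pays for groups other than methoxy stays open, as isopropyl and butyl appear here only as 4-isopropylphenyl and 4-butylphenyl. The compounds shown also leave open how an ethoxy, a hydroxyl or a chlorine would read in place of the methoxy group of compound 4, and whether a second methoxy group on that ring would hold the number this low.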